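A Second Chlorine on the Aryl Ether of Compound 1

This account rests on a few compounds, and the source may have more. Where it says the series, first, only, none or still open, it means among the compounds named here.

For the measured compounds named here, compound 1 `NC1=NC2(CCSCC2)N(OCCCOc2cccc(Cl)c2)C(N)=N1` is the only compound in this set for which a number exists. In an assay on isolated protein for inhibition of Dihydrofolate reductase (Homo sapiens), read by spectrophotometry, using NADPH, with stated times of 5 s and 6 min, tested at 50 uM (on this read-out higher numbers stand for a stronger effect at the one concentration tested and lower numbers for a weaker effect), compound 1 gives 88.8%, a high read-out at the single concentration tested. Compound 2 `NC1=NC2(CCOCC2)N(OCCCOc2cc(Cl)c(Cl)cc2Cl)C(N)=N1` belongs to the same family, but in this assay compound 2 is recorded as "not determined" (no result reported), so it offers no number to compare against. Compound 1 therefore stands alone.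

Compound 3 `NC1=NC2(CCSCC2)N(OCCCOc2cccc(Cl)c2Cl)C(N)=N1` has not yet been tested in this assay. It differs from compound 1 in one place: chloro in place of hydrogen on an aromatic carbon. Everything else in the molecule, including the shared core, is unchanged.

Going by the values given here, since no measured pair in this set shows what this change does, the expectation rests on compound 1 alone. Because compound 1 already gives 88.8%, little room remains for a rise, and a fall beyond the usual scatter is not suggested by anything shown. The step expected in this assay is a number 0.8 percentage points lower from compound 1 to compound 3 (within the scatter), within the scatter. Compound 3 is expected to give 88% in this assay, with a range from 78% to 95%.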

Compound 3, a percentage reported as inhibition, at one concentration (the size of the read-out at that concentration, not a potency): 89.8%
Estimate against measurement, compound 3: 1.8 percentage points below; the measured number falls inside the stated range.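

For the compounds shown here, compound 1 and compound 3 form the first measured pair in this set, and it shows what adding a second chlorine does in this assay: the change from 3-chlorophenyl to 2,3-dichlorophenyl gives a number 1 percentage points higher from compound 1 to compound 3 (within the scatter), so the two compounds cannot be told apart on this read-out. A chloro group can therefore stand on this aromatic carbon, ortho to a chloro group, while the read-out stays high, although a result at one concentration is not a potency and could conceal a difference that a full concentration series would reveal. Nothing shown here explains why this swap of hydrogen for chloro leaves the read-out unmoved.

The compounds shown leave open whether another group on this same carbon, such as a methoxy group, an amine or a carboxylic acid, would also keep the read-out high. They also leave open whether the same swap of hydrogen for chloro would give a similar result on a different core or with a longer chain linking the aryl ether to it.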